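This account rests on a few compounds, and the source may have more. Where it says the series, first, only, none or still open, it means among the compounds named here.

Measured in a functional assay on PC-3 cells (Homo sapiens) for inhibition, read by MTT assay, with a stated time of 48 h; on this read-out higher numbers stand for weaker inhibition and lower numbers for stronger inhibition:
Compound 1 `COc1ccc(-c2coc3cc(OCCCSC(=S)N4CCN(C)CC4)ccc3c2=O)cc1`: 2210 nM
Compound 2 `COc1ccc(-c2coc3cc(OCCCSC(=S)N4CCN(c5ccccn5)CC4)ccc3c2=O)cc1`: 17400 nM

Compound 2 stands highest of the two measured compounds, which makes it the weaker inhibitor here. Among the measured compounds shown here, the one measured step, a 7.9-fold higher number from compound 1 to compound 2 (0.90 log units; beyond the scatter), put pyridin-2-yl in place of methyl on an amine nitrogen in a ring. Compound 3 `COc1ccc(-c2coc3cc(OCCCSC(=S)N4CCN(C(=O)OC(C)(C)C)CC4)ccc3c2=O)cc1` is changed on that same nitrogen, with tert-butoxycarbonyl in place of pyridin-2-yl on an amine nitrogen in a ring.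

For the measured compounds named here, that single step is the only evidence at this place. Going by the values given here, it shows that the group on this nitrogen can move the number, but no measured compound carries anything like tert-butoxycarbonyl, so the direction remains uncertain. Among the compounds with values here, compound 2 at 17400 nM is the higher of only two values, so a moderate move toward lower numbers is expected, smaller than the measured step. The estimated change is a 2.2-fold lower number from compound 2 to compound 3 (0.34 log units; beyond the scatter). For compound 3 the expected value is 8000 nM, with an estimated range from 2500 nM to 25000 nM.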

Compound 3, half-maximal inhibitory concentration: 1970 nM
For compound 3 the middle estimate is 4.1-fold (0.61 log units) above the measured one; measured number outside the range, below it.
By their numbers in this assay, from the lowest: compounds 3 and 1 (each within the scatter of the next); then compound 2.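

In this assay, the change on the amine nitrogen in the ring gives an 8.8-fold lower number from compound 2 to compound 3 (0.95 log units; beyond the scatter), so a second group now reverses the loss seen with pyridin-2-yl. Methyl and tert-butoxycarbonyl are not told apart at this position, with a 1.1-fold lower number from compound 1 to compound 3 (0.05 log units; within the scatter), although one is a single carbon group and the other a carbonyl-bearing group; among these three compounds, only the pyridin-2-yl of compound 2 stands apart, and the higher number is therefore not a general result of changing the group on this nitrogen. Nothing at hand accounts for why pyridin-2-yl differs from the other two groups.

The three compounds cannot show whether the higher number goes with an aromatic ring on this nitrogen in general or with pyridin-2-yl in particular, and a phenyl group here would separate the ring from its nitrogen. An acetyl group or a plain hydrogen on the same nitrogen would show how far the range shared by compound 1 and compound 3 extends.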